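A Pyridine Swap on a Weakly Binding Benzyloxy Analogue

A few compounds are considered here, and "the series" means these few. Any claim that something is new, unique, unknown or untested is made for them only; others in the source may bear on it.

Compound 1, `CC1(C)OB(c2ccc(COc3ccc(CNC(=O)[C@@H]4CCC(=O)N4Cc4ccccc4)cc3)cc2)OC1(C)C`, gives 50 nM in this assay.
Compound 2, `O=C(NCc1ccc(OCc2ccccc2)cc1)[C@@H]1CCC(=O)N1Cc1ccccc1`, gives only a limit, > 5000 nM.
Compound 3, `O=C(O)c1ccc(COc2ccc(CNC(=O)[C@@H]3CCC(=O)N3Cc3ccc(C(F)(F)F)cc3)cc2)cc1`, gives only a limit, > 5000 nM.

Among the compounds with values here, in an assay on HEK293 cells for inhibition of Ataxin-2 (Mus musculus), read by fluorescence and Amplex Red (a higher number here means a weaker inhibitor, a lower number a stronger inhibitor), compound 1 is the only one with a number. For compound 2 the result is a limit of the assay, > 5000 nM, so it stands at the limit of > 5000 nM in this assay, at which 2 of the 3 values shown sit. Within the data shown here, the single measured step, an at least 100-fold higher number from compound 1 to compound 2 (2.00 log units; beyond the scatter), concerns the same ring that is altered here and shows that a large change on it moves the value far. Compound 4, `O=C(NCc1ccc(OCc2ccncc2)cc1)[C@@H]1CCC(=O)N1Cc1ccccc1`, differs from compound 2 by pyridin-4-yl in place of phenyl on a saturated chain carbon bound to an oxygen on an aromatic ring. Among the measured compounds shown here, this change is much smaller than the one in that step, and no measured step bears on it directly, so compound 4 is expected to remain at or near the limit, with a step that the limit leaves unreadable from compound 2 to compound 4. The estimate for compound 4 is 6000 nM, spanning 1500 nM to 25000 nM.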

Compound 4, half-maximal inhibitory concentration: > 5000 nM
Compound 4: a limit, no number (the forecaster's own chance of this, stated with the estimate: 80%); the middle value is on the limit's open side.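

In this assay compound 4 gives > 5000 nM, which is a limit and not a number. Compound 2 also stands at a limit, so the step between compound 2 and compound 4 cannot be read. The compounds shown leave open whether pyridin-4-yl in place of phenyl moves the value at all.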